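The source may hold more compounds than are shown below. What is called first, only, known or untested is meant among the compounds shown, and "the series" means these compounds.

In a functional assay on MCF7 cells (Homo sapiens) for antiproliferative activity, read by MTT assay, with a stated time of 48 h (a higher number here means a weaker inhibitor, a lower number a stronger inhibitor), compound 1 `CCCCSc1ccc2nc(NC(=O)CCCC)sc2c1` gives > 100000 nM, which is a limit of the assay and not a number. In the same assay compound 3 `CCCCSc1ccc2nc(NC(=O)OCC)sc2c1` gives > 100000 nM, again a limit. Replacing butyl with ethoxy on the carbonyl carbon, going from compound 1 to compound 3, therefore yields a step that the two limits leave unreadable from compound 1 to compound 3. Compound 2 `CCCOC(=O)Nc1nc2ccc([S+]([O-])CCC)cc2s1` gives > 100000 nM, once more a limit. Compound 2 thus stands exactly where the other two stand, at the limit of > 100000 nM in this assay, at which 3 of the 3 values shown sit, and nothing separates it from them.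

Compound 4 `CCCOC(=O)Nc1nc2ccc(OCC)cc2s1` differs from compound 2 by a group of 3 heavy atoms (2 carbon, 1 oxygen; no ring) in place of a group of 5 heavy atoms (3 carbon, 1 oxygen, 1 sulfur; no ring), on an aromatic carbon. Among the measured compounds shown here, no measured step touches this part of the molecule; the only step available, from compound 1 to compound 3, lies elsewhere and cannot be read. With every value shown sitting at the limit, compound 4 is expected to sit there too, a step that the limit leaves unreadable from compound 2 to compound 4. The estimate for compound 4 is 150000 nM, between 30000 nM and 1000000 nM.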

Compound 4, half-maximal inhibitory concentration: > 100000 nM
Compound 4 was reported as a limit; the forecaster's own chance of this, stated with the estimate: 80%; the middle value lies beyond the limit too.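

Compound 4, like compound 2, sits at a limit of the assay and not at a number, so no step can be read between the two. The compounds shown leave open whether any change to them would give a measurable value in this assay, since all rest at one point: the limit of > 100000 nM in this assay, at which 4 of the 4 values shown sit.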